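Adding a Second Chloro to the Purine-like Core

The source may report more compounds than this note shows. Statements on the series, on what has been measured and on what is new or still open speak of the compounds shown alone.

Of the compounds shown here, two have been measured so far for their ability to slow the growth of a colon cancer cell line. Compound 1 `ClCc1cccc(Cn2cnc3c(Cl)nc(Cl)nc32)c1` gives 2390 nM in a functional assay on HCT-15 cells (Homo sapiens) for cytotoxicity, read by sulforhodamine B assay, with a stated time of 48 h; a lower number here means a stronger inhibitor of growth, a higher number a weaker inhibitor of growth. Compound 2 `ClCc1ccccc1Cn1cnc2ncnc(Cl)c21` gives 1380 nM in this assay, the lower of the two numbers, though the gap to compound 1 is small enough to fall within the ordinary scatter of such cell-based measurements, so the two cannot be ranked against each other.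

Compound 3 `ClCc1ccccc1Cn1cnc2nc(Cl)nc(Cl)c21` has not yet been measured. It differs from compound 2 in one place: chloro in place of hydrogen on an aromatic carbon, on the six-membered ring of the shared core, between two ring nitrogen atoms, meta to the existing chloro group. Within the data shown here, no directly comparable pair of measured compounds shows this exact change. Compound 1 already carries the same pair of chloro groups on its core and sits close to compound 2, so the change is not expected to move the number beyond the scatter in either direction. Compound 3 is therefore expected to give about 1500 nM in this assay, somewhere between 600 nM and 4000 nM. That expectation corresponds to a step of a 1.1-fold higher number from compound 2 to compound 3 (0.04 log units; within the scatter) of essentially nothing.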

Compound 3, concentration for 50% growth inhibition: 190 nM
Estimate against measurement, compound 3: 7.9-fold (0.90 log units) above; the measured number lies below the stated range.
By their numbers in this assay, from the lowest: compound 3; then compounds 2 and 1 (each within the scatter of the next).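

In this assay, chloro in place of hydrogen on an aromatic carbon, between two ring nitrogen atoms, brings a 7.3-fold lower number from compound 2 to compound 3 (0.86 log units; beyond the scatter), the first step beyond the scatter among the compounds shown, so what stands at this spot on the shared core can clearly matter. The pair of chloro groups does not settle the number alone: compound 1 carries both on its core and gives 2390 nM, while compound 3, with its chloromethyl group placed differently, gives 190 nM. Nothing measured here accounts for the size of this step, so the reason for it remains unknown.

The compounds shown leave open whether chloro in particular is needed at this spot, or whether another group there, such as an amine or a methoxy group, would give a similar number. They also leave open whether adding or removing this chloro would move the number as far with the chloromethyl group placed as in compound 1, and whether the low number of compound 3 would hold in other cell lines.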